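Dropping a Chlorine from a Nitrophenyl Amine

This account rests on a few compounds, and the source may have more. Where it says the series, first, only, none or still open, it means among the compounds named here.

Compound 2 `CCOC(=O)C1=C(C)NC(=O)NC1c1cn(C(=O)CNc2ccc([N+](=O)[O-])cc2Cl)c2ccccc12` carries a urea in its core and a 2-chloro-4-nitrophenyl group on an amine nitrogen. In a physicochemical assay for lipophilicity (on this read-out lower numbers stand for lower lipophilicity and higher numbers for higher lipophilicity), compound 2 gives 1.99, the lowest of the three numbers measured. Its two companions carry a thiourea instead: compound 1 `CCOC(=O)C1=C(C)NC(=S)NC1c1cn(C(=O)CNc2ccccc2Cl)c2ccccc12` gives 3.44 and compound 3 `CCOC(=O)C1=C(C)NC(=S)NC1c1cn(C(=O)CNc2ccc([N+](=O)[O-])cc2C)c2ccccc12` gives 3.34, each beyond the scatter above compound 2. Among the compounds with values here, the only measured step between compounds that differ in a single place, a number 0.10 log units lower from compound 1 to compound 3 (within the scatter), exchanges one aryl group for another on the amine nitrogen and stays within the scatter. Compound 4 `CCOC(=O)C1=C(C)NC(=O)NC1c1cn(C(=O)CNc2ccccc2[N+](=O)[O-])c2ccccc12` differs from compound 2 in one place: 2-nitrophenyl in place of 2-chloro-4-nitrophenyl on an amine nitrogen. Within the data shown here, no measured step covers this exact swap, and the step from compound 1 to compound 3 touched a different pair of groups, so the guidance is thin; what is clear is that the chlorine leaves with the departing group while the nitro group remains. A modest downward step a number 0.54 log units lower from compound 2 to compound 4 (beyond the scatter) is expected in this assay. Compound 4 is therefore estimated at 1.45, in a range from 0.95 to 1.95.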

Compound 4, partition coefficient: 1.48
The estimate for compound 4 lay 0.03 log units below the measured number, within the range that was stated.
By their numbers in this assay, from the lowest: compound 4; then compound 2; then compounds 3 and 1 (each within the scatter of the next).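

In the urea compounds, the aryl group on the amine nitrogen clearly affects this assay: replacing it gives a number 0.51 log units lower from compound 2 to compound 4 (beyond the scatter), whereas the earlier single-place step, a number 0.10 log units lower from compound 1 to compound 3 (within the scatter), showed no such separation. The group names show two differences at once, since the chlorine is gone and the nitro group's number changes from 4 to 2, while the counts of hydrogen-bond donors and acceptors stay the same. No measurement at hand explains this step.

The compounds shown leave open how much of the step belongs to losing the chlorine and how much to the changed nitro numbering, as no compound separates the two. They also leave open how the same position would read with a methoxy group or a carboxylic acid on the phenyl ring, or how this swap would read in the thiourea compounds.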